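Swapping Methylsulfanyl for Methoxy on a Weak Growth Inhibitor

The source may hold more compounds than are shown below. What is called first, only, known or untested is meant among the compounds shown, and "the series" means these compounds.

In a functional assay on DU-145 cells (Homo sapiens) for inhibition, read by trypan blue exclusion, with a stated time of 96 h (on this read-out higher numbers stand for weaker inhibition of growth and lower numbers for stronger inhibition of growth), compound 1 (`COc1ccc(/C=C(/Sc2ccc(C)cc2)C(=O)c2ccc(Cl)cc2)cc1`) gives 1000 nM and compound 2 (`CSc1ccc(/C=C(/SCc2ccc(Cl)cc2)C(=O)c2ccc(Cl)cc2)cc1`) gives 25000 nM. Compound 2 therefore has the higher of the two numbers and the weaker inhibition, by a gap beyond the scatter. Compound 3 (`COc1ccc(/C=C(/SCc2ccc(Cl)cc2)C(=O)c2ccc(Cl)cc2)cc1`) has methoxy in place of methylsulfanyl on an aromatic carbon. Compound 2 differs from compound 1 in other places too, so the methoxy-bearing compound 1 at 1000 nM is only a loose guide. A modest fall in this assay is expected for the step of a 2.5-fold lower number from compound 2 to compound 3 (0.40 log units; beyond the scatter). Compound 3 is estimated at 10000 nM, with an expected range of 2500 nM to 40000 nM.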

Compound 3, concentration for 50% growth inhibition: 10000 nM
Estimate against measurement, compound 3: no gap at the digits printed, and the stated range covers the measured number.
By their numbers in this assay, from the lowest: compound 1; then compound 3; then compound 2.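

Within the data shown here, changing only this one group, from 4-(methylsulfanyl)phenyl to 4-methoxyphenyl, gives a 2.5-fold lower number from compound 2 to compound 3 (0.40 log units; beyond the scatter) in this assay, so this position on the ring responds to the swap and methoxy gives the stronger inhibition of growth. With methoxy now shared, the group on sulfur can also be read alone: 4-chlorobenzyl in place of 4-methylphenyl gives a 10-fold higher number from compound 1 to compound 3 (1.00 log units; beyond the scatter), a larger step than the swap on the aromatic carbon. Nothing shown here explains either step.

From the compounds shown here alone, whether ethoxy or a dimethylamino group would do better at this position remains open. So does whether the swap to methoxy has the same effect with 4-methylphenyl on the sulfur.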